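The compounds below may be only part of what the source reports. "The series", "measured", "known", "first", "only" and "open" are said of these compounds alone.

Working notes on the series.

Two compounds carry a number in an in vitro assay on CHO cells for displacement of a labelled ligand from Bombesin receptor subtype-3 (Homo sapiens), read by scintillation counting, with a stated time of 2 h; a higher number here means a weaker inhibitor, a lower number a stronger inhibitor. Compound 1 `CCC(C)(C)Cc1c[nH]c(CCc2ccc(-c3ccccc3C(=O)O)cc2)n1` gives 11 nM in this assay, the lowest of the two numbers. Within the data shown here, compound 2 `c1ccc(-c2ccc(CCc3nc(CC4CCCC4)c[nH]3)cc2)nc1` gives 177 nM in this assay, a number higher than that of compound 1 by a margin that lies beyond the scatter; compound 2 also differs from compound 1 in more than one place, so no single step is drawn between them.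

Compound 3 `CCC(C)(C)Cc1c[nH]c(CCc2ccc(N3CCCCC3)cc2)n1` is not yet measured in this assay. It differs from compound 1 in one place: piperidin-1-yl in place of 2-carboxyphenyl on an aromatic carbon. Among the measured compounds shown here, no measured pair shows this kind of change, so the size of its step in this assay cannot be read from a neighbour. For the measured compounds named here, the only guide is that the two numbers known so far sit well apart, and that the group leaving is the larger one. The expectation is a step up in number, beyond the scatter, estimated as a 7.3-fold higher number from compound 1 to compound 3 (0.86 log units; beyond the scatter). Compound 3 is therefore estimated at 80 nM in this assay, with a range from 20 nM to 400 nM.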

Compound 3, half-maximal inhibitory concentration: 28 nM
The estimate for compound 3 lay 2.9-fold (0.46 log units) above the measured number; the range from low to high includes it.
By their numbers in this assay, from the lowest: compound 1; then compound 3; then compound 2.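

In this assay, among these compounds, the change of 2-carboxyphenyl to piperidin-1-yl, on an aromatic carbon para to a large group, gives the first single-place step: a 2.5-fold higher number from compound 1 to compound 3 (0.41 log units; beyond the scatter), beyond the scatter but modest. This place therefore tolerates the loss of the six-membered aromatic ring, the hydrogen-bond donor and the double bond outside aromatic rings in a single change, with compound 3 at 28 nM, so activity here does not hang entirely on the 2-carboxyphenyl group. Nothing available explains the size of this step.

The compounds shown leave open which part of the change carries the step, as the aromatic ring and the carboxylic acid leave together and a non-aromatic ring bearing a nitrogen enters in the same move. A plain phenyl group at this place, which keeps the aromatic ring without the carboxylic acid, and a piperidin-1-yl ring carrying a carboxylic acid, which keeps the acid without the aromatic ring, would separate these contributions.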